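A few compounds are considered here, and "the series" means these few. Any claim that something is new, unique, unknown or untested is made for them only; others in the source may bear on it.

Compound 3 `CCC(CC)Nc1nc(C)nc2c1nnn2-c1c(C)cc(C)cc1C` stands lowest of the three numbers in hand: in an in vitro assay on 293-EBNA cells for binding affinity to corticotropin-releasing factor receptor 1 (Homo sapiens) (on this read-out lower numbers stand for stronger inhibition and higher numbers for weaker inhibition), compound 3 gives 5.7 nM, its nearest neighbour being compound 2 `CCC(COC)Nc1nc(C)nc2c1nnn2-c1c(C)cc(C)cc1C`, which in this assay gives 59.4 nM, and the furthest compound 1 `COCCNc1nc(C)nc2c1nnn2-c1c(C)cc(C)cc1C`, which gives 1200 nM. Those three numbers fall as steps of a 20-fold lower number from compound 1 to compound 2 (1.31 log units; beyond the scatter), a 10-fold lower number from compound 2 to compound 3 (1.02 log units; beyond the scatter) and a 210-fold lower number from compound 1 to compound 3 (2.32 log units; beyond the scatter).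

Compound 4 `CCCCC(CC)Nc1nc(C)nc2c1nnn2-c1c(C)cc(C)cc1C` differs from compound 3 by ethyl in place of hydrogen on a saturated chain carbon, three bonds along the chain from a nitrogen on an aromatic ring. For the measured compounds named here, no measured pair changes this particular carbon. Going by the values given here, the steps that bear on it are the chain changes on the same nitrogen: a 20-fold lower number from compound 1 to compound 2 (1.31 log units; beyond the scatter), where an ethyl entered on the carbon bound to the nitrogen, and a 10-fold lower number from compound 2 to compound 3 (1.02 log units; beyond the scatter), where a methyl replaced a methoxy. Both were large, but both sit closer to the nitrogen, and compound 3 already carries the pentan-3-yl that those steps built. An ethyl added further out is therefore expected to give a step of a 1.4-fold higher number from compound 3 to compound 4 (0.15 log units; within the scatter), not beyond the scatter. Compound 4 is expected to give about 8 nM, between 2.5 nM and 30 nM.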

Compound 4, inhibition constant: 7.6 nM
Compound 4: middle estimate off by 1.1-fold (0.02 log units), on the high side; the range from low to high includes it.
By their numbers in this assay, from the lowest: compounds 3 and 4 (each within the scatter of the next); then compound 2; then compound 1.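

Placing an ethyl in place of hydrogen on a saturated chain carbon, three bonds along the chain from a nitrogen on an aromatic ring, leaves the read-out unmoved, with a 1.3-fold higher number from compound 3 to compound 4 (0.12 log units; within the scatter), so the chain can grow to 1-ethylpentyl here without a loss beyond the scatter. Compound 4 also keeps its distance from the two compounds that carry a methoxy, with a 7.8-fold lower number from compound 2 to compound 4 (0.89 log units; beyond the scatter) and a 160-fold lower number from compound 1 to compound 4 (2.20 log units; beyond the scatter). The same ethyl for hydrogen change therefore counts for very different amounts depending on the chain it enters: the same change on two cores in this assay, a 20-fold lower number (1.31 log units; beyond the scatter) from compound 1 to compound 2 and a 1.3-fold higher number (0.12 log units; within the scatter) from compound 3 to compound 4, 27-fold (1.43 log units) apart, beyond the scatter of two such steps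

The compounds shown leave open whether a longer chain at this carbon would also stay within the scatter of compound 3. They also leave open whether an amine or a carboxylic acid would be accepted on this same carbon.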